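This account rests on a few compounds, and the source may have more. Where it says the series, first, only, none or still open, it means among the compounds named here.

In a functional assay on HepG2 cells (Homo sapiens) for cytotoxicity, read by MTT assay (on this read-out lower numbers stand for stronger inhibition and higher numbers for weaker inhibition), compound 1 `COc1ccc(/C=C/C(=O)c2ccc(OC)c3c2OC(C)(C)C=C3)cc1O` gives 450 nM as its half-maximal inhibitory concentration. Compound 2 `COc1ccc(/C=C/C(=O)c2ccc(OC)c3c2OC(C)(C)C=C3)cc1OCC=C(C)C` stands at > 10000 nM in this assay and that figure is a limit, not a number. The change to compound 3 `C#CCOc1cc(/C=C/C(=O)c2ccc(OC)c3c2OC(C)(C)C=C3)ccc1OC` is ethynyl in place of 2-methylprop-1-en-1-yl on a saturated chain carbon bound to an oxygen on an aromatic ring and reads as 3-methylbut-2-en-1-yl to propargyl. Within the data shown here, the one measured step bearing on it is an at least 22-fold higher number from compound 1 to compound 2 (1.34 log units; beyond the scatter) on placing 3-methylbut-2-en-1-yl on that oxygen. Compound 3 still carries a group there, so only a moderate step toward lower numbers is expected, estimated as an at least 3.3-fold lower number from compound 2 to compound 3 (0.52 log units; beyond the scatter) in this assay overall. For compound 3 the expected value is 3000 nM within an estimated range of 600 nM to 10000 nM for now.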

Compound 3, half-maximal inhibitory concentration: > 10000 nM
Compound 3 was reported as a limit; the forecaster's own chance of this, stated with the estimate: 35%; middle value at least 3.3-fold (0.52 log units) from the limit.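

In this assay, propargyl on this oxygen also costs the activity of the free hydroxyl: an at least 22-fold higher number from compound 1 to compound 3 (1.34 log units; beyond the scatter). The loss seen with 3-methylbut-2-en-1-yl is therefore not confined to that group, and it persists with ethynyl in place of 2-methylprop-1-en-1-yl. The step between compound 2 and compound 3 cannot be read, and compound 3 has only a limit, not a number: the limit of > 10000 nM in this assay, at which 2 of the 3 values shown sit.

Still open, as far as these compounds go, is whether methyl or a chain ending in an amine on this oxygen would stay near compound 1 at 450 nM.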